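Swapping the aryl group on the amine of a quinazoline-like core

This account rests on a few compounds, and the source may have more. Where it says the series, first, only, none or still open, it means among the compounds named here.

Measured so far:
compound 1, `CCCCCCCCNc1nc(SCc2ccc(C(F)(F)F)cc2)nc2ccccc12`: 26100 nM
compound 2, `FC(F)(F)c1ccc(CSc2nc(Nc3ccccc3)c3ccccc3n2)cc1`: 44000 nM
compound 3, `FC(F)(F)c1ccc(CSc2nc(Nc3cccc(Cl)c3)c3ccccc3n2)cc1`: 25100 nM

All three share one core and differ only in the group on a nitrogen on an aromatic ring. In a functional assay on MCF7 cells (Homo sapiens) for cytotoxicity, read by MTT assay, with a stated time of 72 h (a lower number here means a stronger inhibitor, a higher number a weaker inhibitor), compound 3 gives 25100 nM, which sits at the low end of the three numbers, yet every pair among the three lies within the usual scatter of each other.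

Compound 4, `COc1ccc(Nc2nc(SCc3ccc(C(F)(F)F)cc3)nc3ccccc23)cc1`, has not yet been measured. It differs from compound 3 in one place: 4-methoxyphenyl in place of 3-chlorophenyl on a nitrogen on an aromatic ring.

Among the measured compounds shown here, two measured steps bear on this kind of change. Replacing the octyl chain by an aryl group gave a 1.0-fold lower number from compound 1 to compound 3 (0.02 log units; within the scatter), and putting chloro in place of hydrogen on that aryl ring gave a 1.8-fold lower number from compound 2 to compound 3 (0.24 log units; within the scatter). Neither change moved the number beyond the scatter, so a further swap of the aryl group is expected to give no step beyond the scatter in this assay, and the estimated step is a 1.2-fold higher number from compound 3 to compound 4 (0.08 log units; within the scatter).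

Compound 4 is therefore expected to give about 30000 nM, most likely between 12000 nM and 75000 nM.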

Compound 4, half-maximal inhibitory concentration: 47200 nM
Compound 4: the middle estimate sits 1.6-fold (0.20 log units) below what was measured, within the range that was stated.
By their numbers in this assay, from the lowest: compounds 3, 1, 2 and 4 (each within the scatter of the next).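

Measured in this assay the swap to 4-methoxyphenyl gives a 1.9-fold higher number from compound 3 to compound 4 (0.27 log units; within the scatter) and adding methoxy to the phenyl ring gives a 1.1-fold higher number from compound 2 to compound 4 (0.03 log units; within the scatter) while replacing the octyl chain with 4-methoxyphenyl gives a 1.8-fold higher number from compound 1 to compound 4 (0.26 log units; within the scatter) so this nitrogen has now carried a fourth group without any step leaving the scatter. A ring bearing methoxy, which brings a hydrogen-bond acceptor into the group, therefore cannot be told apart from a ring bearing chloro, a bare phenyl ring or the octyl chain. All four numbers lie within the scatter of one another, so no group here stands out at this position.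

From the compounds shown here alone, whether an amine or a carboxylic acid on this nitrogen would move the number beyond the scatter stays open. Nothing available explains why the four numbers lie so close.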